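The source may hold more compounds than are shown below. What is called first, only, known or untested is meant among the compounds shown, and "the series" means these compounds.

Compound 3 `CCNC(=O)Nc1ccc(S(=O)(=O)Oc2ccccc2C(C)C)cc1` has the lowest number of the three measured compounds in a functional assay on HT-1080 cells (Homo sapiens) for antiproliferative activity, read by sulforhodamine B assay, with a stated time of 48 h (a higher number here means a weaker inhibitor, a lower number a stronger inhibitor), where compound 3 gives 250 nM. Among the measured compounds shown here, the two compounds carrying an iodo group on the second ring are compound 1 `CC(C)C(=O)Nc1ccc(S(=O)(=O)Oc2ccccc2I)cc1`, which gives 3300 nM, and compound 2 `CC(C)(C)C(=O)Nc1ccc(S(=O)(=O)Oc2ccccc2I)cc1`, which gives 2600 nM; the only measured step, a 1.3-fold lower number from compound 1 to compound 2 (0.10 log units; within the scatter), concerns the amide end of the molecule and not the group on the second ring. Compound 4 `CCNC(=O)Nc1ccc(S(=O)(=O)Oc2ccccc2I)cc1` keeps the ethyl urea of compound 3 and differs by iodo in place of isopropyl on an aromatic carbon. For the measured compounds named here, no measured step covers that swap directly, so the expectation rests on the shared iodo of compound 1 and compound 2 and stays wide. Compound 4 is expected to show a 2.8-fold higher number from compound 3 to compound 4 (0.45 log units; beyond the scatter), with an estimate of 700 nM between 150 nM and 3000 nM.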

Compound 4, half-maximal inhibitory concentration: 140 nM
Compound 4: middle estimate off by 5.0-fold (0.70 log units), on the high side; the measured number lies below the stated range.
By their numbers in this assay, from the lowest: compounds 4 and 3 (each within the scatter of the next); then compounds 2 and 1 (each within the scatter of the next).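

At this aromatic carbon, a single iodine atom serves as well as the three carbons of isopropyl in this assay (a 1.8-fold lower number from compound 3 to compound 4 (0.25 log units; within the scatter)). With iodo held fixed, replacing the group on the carbonyl carbon with ethylamino gives large steps, both from tert-butyl (a 19-fold lower number from compound 2 to compound 4 (1.27 log units; beyond the scatter)) and from isopropyl (a 24-fold lower number from compound 1 to compound 4 (1.37 log units; beyond the scatter)). Nothing available explains either result.

On these data alone, whether this aromatic carbon would accept a much smaller group, such as fluoro or methyl, remains open. So does the effect of a longer chain, such as butylamino, on the carbonyl carbon.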